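The source may hold more compounds than are shown below. What is called first, only, known or untested is meant among the compounds shown, and "the series" means these compounds.

In a functional assay on A549 cells (Homo sapiens) for cytotoxicity, read by MTT assay, with a stated time of 72 h (on this read-out higher numbers stand for weaker inhibition and lower numbers for stronger inhibition), compound 3 (`O=C(CN1CCN(c2nnc(Cc3ccncc3)c3ccccc23)CC1)Nc1ccc(F)c(Cl)c1`) gives 12300 nM. This lies within the scatter of compound 2 (`Cc1cccc(Cl)c1NC(=O)CN1CCN(c2nnc(Cc3ccccc3)c3ccccc23)CC1`) at 7420 nM, while compound 1 (`O=C(CN1CCN(c2nnc(Cc3ccncc3)c3ccccc23)CC1)Nc1cccc(Br)c1`) gives a lower number, 1530 nM. Compound 4 (`Cc1cccc(Cl)c1NC(=O)CN1CCN(c2nnc(Cc3ccncc3)c3ccccc23)CC1`) has 2-chloro-6-methylphenyl in place of 3-chloro-4-fluorophenyl on an amide-type nitrogen. Within the data shown here, the one measured step at this place is an 8.0-fold higher number from compound 1 to compound 3 (0.91 log units; beyond the scatter), so a change here can exceed the scatter. However, compound 2 already carries 2-chloro-6-methylphenyl on its amide-type nitrogen and gives 7420 nM, though elsewhere it differs from compound 4. No step beyond the scatter is therefore expected in this assay. The expected step is a 1.8-fold lower number from compound 3 to compound 4 (0.24 log units; within the scatter). For compound 4 the estimated value is 7000 nM, with an expected range of 2500 nM to 18000 nM.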

Compound 4, half-maximal inhibitory concentration: 7190 nM
Estimate against measurement, compound 4: 1.0-fold (0.01 log units) below; low and high end bracket the measured number.
By their numbers in this assay, from the lowest: compound 1; then compounds 4, 2 and 3 (each within the scatter of the next).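

In this assay, a third group at the amide-type nitrogen gives a 1.7-fold lower number from compound 3 to compound 4 (0.23 log units; within the scatter), while a 4.7-fold higher number from compound 1 to compound 4 (0.67 log units; beyond the scatter); among these three groups, only 3-bromophenyl stands apart. Among these compounds, the first step at the other site, pyridin-4-yl in place of phenyl on a saturated chain carbon bound to an aromatic carbon, is a 1.0-fold lower number from compound 2 to compound 4 (0.01 log units; within the scatter), so this swap leaves the read-out within the scatter when 2-chloro-6-methylphenyl is on the amide-type nitrogen. Nothing measured in this set gives a cause for these steps.

Going by these compounds, whether the same swap stays within the scatter with 3-bromophenyl on the amide-type nitrogen remains open. Also open, on these data alone, is how a carboxyphenyl or aminophenyl group would read at that nitrogen.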